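Swapping an Imidazolylpropyl Tail on an Amide

The source may hold more compounds than are shown below. What is called first, only, known or untested is meant among the compounds shown, and "the series" means these compounds.

Measured so far in an assay on isolated protein for inhibition of Rho-associated protein kinase 2 (Homo sapiens), read by HTRF, tested at 10 uM; a lower number here means less inhibition, a higher number more inhibition at the concentration tested (going by the name of the read-out):
Compound 1, `Cc1cccc(Oc2ccnc(N3CCC[C@H]3C(=O)NCc3cccnc3)n2)c1`: 0%
Compound 2, `Cc1cccc(Oc2ccnc(N3CCC[C@H]3C(=O)NCCCn3ccnc3)n2)c1`: 0%

Compound 2 stands level with compound 1 at the digits shown; the only measured step, no change at the digits printed from compound 1 to compound 2 (within the scatter), lies within the scatter. Both compounds therefore show no measurable inhibition in this assay.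

Compound 3, `COC(=O)C(CO)NC(=O)[C@@H]1CCCN1c1nccc(Oc2cccc(C)c2)n1`, is the next step from compound 2. The change is 2-hydroxy-1-(methoxycarbonyl)ethyl in place of 3-(1H-imidazol-1-yl)propyl on an amide-type nitrogen.

Within the data shown here, only the step from compound 1 to compound 2 bears on this new change, since it also alters the group on the amide-type nitrogen, and it produced no change beyond the scatter. Among the measured compounds shown here, nothing measured so far shows any group on that nitrogen lifting inhibition. The expectation for compound 3 is therefore no step beyond the scatter, no change at the digits printed from compound 2 to compound 3 (within the scatter). Compound 3 is estimated at 0%, with a range from -8% to 12%.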

Compound 3, a percentage reported as inhibition, at one concentration (the size of the read-out at that concentration, not a potency): 0%
Compound 3: the middle estimate sits on the measured number at the digits printed, within the range that was stated.
By their numbers in this assay, from the lowest: compounds 1, 2 and 3 (each within the scatter of the next).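

In this assay, the 2-hydroxy-1-(methoxycarbonyl)ethyl group on the amide-type nitrogen gives no change at the digits printed from compound 2 to compound 3 (within the scatter) and, set against the (pyridin-3-yl)methyl group, no change at the digits printed from compound 1 to compound 3 (within the scatter) as well. Until now, both groups tried on this nitrogen carried a five- or six-membered aromatic ring, whereas the entering group has no ring at all, adding a hydroxyl and a methyl ester instead, and inhibition at the tested concentration still does not appear. No supporting evidence accounts for this flat result.

On these data alone, whether an amine, a carboxylic acid in place of the methyl ester, or a longer chain on this nitrogen would produce any inhibition remains open. So does the effect of changing the shared core, which stays the same in all three compounds.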